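Replacing the sulfamide on the amine of compound 3

This account rests on a few compounds, and the source may have more. Where it says the series, first, only, none or still open, it means among the compounds named here.

Of the compounds shown here, three sharing one core have been measured in an assay on isolated protein for displacement of a labelled ligand from 5-hydroxytryptamine receptor 6 (Homo sapiens); a higher number here means a weaker inhibitor, a lower number a stronger inhibitor. Compound 1 `NC[C@@H]1CCCc2cc(S(=O)(=O)c3cc[nH]c3)ccc21` gives 0.316 nM in this assay. Compound 2 `NC[C@@H]1CCCc2cc(S(=O)(=O)c3cn[nH]c3)ccc21` gives 2 nM, and compound 3 `CN(C)S(=O)(=O)NC[C@@H]1CCCc2cc(S(=O)(=O)c3cccc(F)c3)ccc21` gives 2 nM. Among the compounds with values here, the only step between measured neighbours that differ in one place is a 6.3-fold higher number from compound 1 to compound 2 (0.80 log units; beyond the scatter). Compound 3 therefore stands level with compound 2 at the digits shown, the two together being the highest numbers of the three, and it lies furthest from compound 1, whose number is lower and beyond the scatter. Within the data shown here, compound 1 and compound 3 differ in two places, so their values show only that the pair of changes between them goes with a lower number, not which change carries it.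

Compound 4 `O=C(NC[C@@H]1CCCc2cc(S(=O)(=O)c3cccc(F)c3)ccc21)c1ncc[nH]1` differs from compound 3 by (1H-imidazol-2-yl)carbonyl in place of dimethylsulfamoyl on an amine nitrogen. Among the measured compounds shown here, no measured step bears directly on this change: the one step, from compound 1 to compound 2, alters the ring on the sulfonyl sulfur, while the amine nitrogen of compound 3 and compound 4 is untouched by any measured pair. With nothing to push the number either way, compound 4 is expected to stay close to compound 3, with an estimated step of no change at the digits printed from compound 3 to compound 4 (within the scatter). Compound 4 is therefore estimated at 2 nM in this assay, within a range from 0.5 nM to 8 nM.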

Compound 4, inhibition constant: 15.9 nM
Compound 4: middle estimate off by 8.0-fold (0.90 log units), on the low side; measured number above the stated range.
By their numbers in this assay, from the lowest: compound 1; then compounds 2 and 3 (each within the scatter of the next); then compound 4.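

At the amine nitrogen, in this assay, (1H-imidazol-2-yl)carbonyl in place of dimethylsulfamoyl gives an 8.0-fold higher number from compound 3 to compound 4 (0.90 log units; beyond the scatter), so the group carried there is not interchangeable even with the rest of the molecule unchanged. Alongside a 6.3-fold higher number from compound 1 to compound 2 (0.80 log units; beyond the scatter), this shows that a single change on the amine nitrogen, like one on the sulfonyl sulfur, can move the number beyond the scatter, and both measured steps so far run towards a higher number. No measurement at hand accounts for the rise at the amine nitrogen, so it stands as an observation without an explanation.

The compounds shown leave open whether the higher number goes with the five-membered aromatic ring that enters, with the carbonyl, or with the loss of dimethylsulfamoyl, and how a plain acetyl or methanesulfonyl group on the same amine nitrogen would read. They also leave open whether the step would hold with 1H-pyrrol-3-yl on the sulfonyl sulfur, as this change at the amine nitrogen is seen here with one ring there only.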